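Chloro substitution in an allyloxy ketone series

The source may hold more compounds than are shown below. What is called first, only, known or untested is meant among the compounds shown, and "the series" means these compounds.

Compound 1 `O=C(c1cccnc1)c1ccccc1O` is the parent of the set. In a functional assay on Hep cells (Homo sapiens) for cytotoxicity, read by sulforhodamine B assay, with a stated time of 48 h (a higher number here means a weaker inhibitor, a lower number a stronger inhibitor), compound 1 gives 31000 nM. Compound 2 `O=C(c1cccnc1)c1cc(Cl)ccc1O` carries the change (chloro in place of hydrogen on an aromatic carbon), and in this assay compound 2 gives 27000 nM; the step of a 1.1-fold lower number from compound 1 to compound 2 (0.06 log units; within the scatter) is within the scatter, so the two values are read as alike. Compound 3 `C=CCOc1ccc(Cl)cc1C(=O)c1cccnc1` differs from compound 2 by an allyl on the oxygen; how compound 3 differs from compound 1 as a whole is not broken down here. For compound 3 in this assay only a limit is available, > 100000 nM, which is the limit (the limit of > 100000 nM in this assay, at which 1 of the 3 values shown sits). The step of an at least 3.7-fold higher number from compound 2 to compound 3 (0.56 log units; beyond the scatter) is beyond the scatter and points to a weaker compound, with the true size unknown.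

Compound 4 `C=CCOc1c(Cl)cc(Cl)cc1C(=O)c1cccnc1` is not yet measured. It differs from compound 3 by chloro in place of hydrogen on an aromatic carbon, the same kind of change as that from compound 1 to compound 2, though the place is not the same: in compound 2 the chloro entered meta to a group of 8 heavy atoms and para to a hydroxy group, whereas in compound 4 it enters ortho to an allyloxy group, meta to a chloro group and meta to a group of 8 heavy atoms. Within the data shown here, the only measured instance of this kind of change, a 1.1-fold lower number from compound 1 to compound 2 (0.06 log units; within the scatter), sits within the scatter, so the step from compound 3 to compound 4 is expected to be small as well, a step that the limit leaves unreadable from compound 3 to compound 4. Compound 4 is therefore expected to give about 110000 nM in this assay, most likely between 45000 nM and 300000 nM, with a fair chance that only a limit is reported again.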

Compound 4, half-maximal inhibitory concentration: > 100000 nM
Compound 4: no number, only a limit (the forecaster's own chance of this, stated with the estimate: 65%); the middle value is on the limit's open side.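

No step from compound 3 to compound 4 can be read in this assay, because both results are limits of the assay and not numbers: the limit of > 100000 nM in this assay, at which 2 of the 4 values shown sit.

The compounds shown leave open where compound 3 and compound 4 truly lie, and whether chloro in place of hydrogen changes the value at all once the allyl sits on the oxygen.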